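Adding a methyl to the chalcone-type phenyl ring

A few compounds are considered here, and "the series" means these few. Any claim that something is new, unique, unknown or untested is made for them only; others in the source may bear on it.

In an ADME assay on NIH3T3 cells (Mus musculus) for cytotoxicity, read by MTT assay, with a stated time of 48 h (a higher number here means that more compound is tolerated, a lower number that less compound is tolerated), compound 1 `COc1ccc(C(C)=O)cc1S(=O)(=O)Nc1c(N)nc(SC)[nH]c1=O` reads > 1600000 nM. That value is a limit of the assay and not a number. Within the data shown here, compound 2 `COc1ccc(C(=O)/C=C/c2ccccc2)cc1S(=O)(=O)Nc1c(N)nc(SC)[nH]c1=O` gives 17000 nM, the only true number so far. Among the measured compounds shown here, the one measured step is an at least 94-fold lower number from compound 1 to compound 2 (1.97 log units; beyond the scatter), and it lies well beyond the scatter. It installed the whole 2-phenylethenyl group in place of methyl on a carbonyl carbon.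

Compound 3 `COc1ccc(C(=O)/C=C/c2ccc(C)cc2)cc1S(=O)(=O)Nc1c(N)nc(SC)[nH]c1=O` keeps that group and changes it only at its outer ring: methyl in place of hydrogen on an aromatic carbon, turning phenyl into 4-methylphenyl. For the measured compounds named here, no measured step tests a change of this kind, so the size of the step for compound 2 does not carry over. No step beyond the scatter is expected in this assay, and no direction is favoured. The estimated 1.1-fold lower number from compound 2 to compound 3 (0.03 log units; within the scatter) is small. Compound 3 is expected at 16000 nM, with an estimated range of 7000 nM to 38000 nM.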

Compound 3, concentration lethal to 50% of the cells: 7200 nM
For compound 3 the middle estimate is 2.2-fold (0.35 log units) above the measured one; the measured number falls inside the stated range.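

In this assay, a single methyl on the outer ring, turning phenyl into 4-methylphenyl, gives a 2.4-fold lower number from compound 2 to compound 3 (0.37 log units; beyond the scatter), so this ring responds to substitution and the number does not depend on the 2-phenylethenyl group alone. That step is modest compared with an at least 220-fold lower number from compound 1 to compound 3 (2.34 log units; beyond the scatter), so most of the drop stays with the whole 2-(4-methylphenyl)ethenyl group in place of methyl on a carbonyl carbon. The larger step starts from compound 1, whose value is a limit of the assay and not a number: the limit of > 1600000 nM in this assay, at which 1 of the 3 values shown sits.

As far as these compounds go, whether the smaller step belongs to methyl itself or to any group on this ring stays open; a methoxy, a chlorine or an amine in the same place would test that. Also open, from the compounds shown here alone, is what a saturated ethyl link in place of the ethenyl link would give.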